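Cytotoxicity notes: amide-side aryl replaced by a saturated ring

This account rests on a few compounds, and the source may have more. Where it says the series, first, only, none or still open, it means among the compounds named here.

Compound 1 `Cc1nc2cc(C(=O)NCc3ccc(F)c(C4CC4)c3)nn2c(-c2cc(F)c3c(c2C)CCCO3)c1[C@H](OC(C)(C)C)C(=O)O` is assessed in an ADME assay on MT2 cells (Homo sapiens) for cytotoxicity; a lower number here means that less compound is tolerated, a higher number that more compound is tolerated. Compound 1 gives > 40000 nM there, which is a limit of the assay rather than a number. Compound 2 `COc1cc(F)ccc1CNC(=O)c1cc2nc(C)c([C@H](OC(C)(C)C)C(=O)O)c(-c3cc(F)c4c(c3C)CCCO4)n2n1` gives > 40000 nM in this assay, again a limit. Compound 3 `Cc1nc2cc(C(=O)NCC3CCCCC3)nn2c(-c2cc(F)c3c(c2C)CCCO3)c1[C@H](OC(C)(C)C)C(=O)O` likewise gives > 40000 nM in this assay, also a limit. The steps between them, a step that the two limits leave unreadable from compound 1 to compound 2, a step that the two limits leave unreadable from compound 1 to compound 3 and a step that the two limits leave unreadable from compound 2 to compound 3, are therefore not readable in size; what is visible is the limit of > 40000 nM in this assay, at which 3 of the 3 values shown sit.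

Compound 4 `Cc1nc2cc(C(=O)NCC3CCOCC3)nn2c(-c2cc(F)c3c(c2C)CCCO3)c1[C@H](OC(C)(C)C)C(=O)O` is not yet measured in this assay. It differs from compound 1 thus: oxan-4-yl in place of 3-cyclopropyl-4-fluorophenyl on a saturated chain carbon bound to an amide-type nitrogen. The measured steps exchange the group on the saturated chain carbon bound to the amide-type nitrogen, as this change does, and none of them moved a compound away from the limit. No step beyond the scatter is expected; a step that the limit leaves unreadable from compound 1 to compound 4 is the estimated step. Compound 4 is expected to give 50000 nM in this assay, within 25000 nM to 100000 nM, most likely again reported only as a limit.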

Compound 4, half-maximal cytotoxic concentration: > 40000 nM
Compound 4: only a limit was reported; the forecaster's own chance of this, stated with the estimate: 85%; the middle value does not contradict the limit.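

In this assay compound 4 gives > 40000 nM, which is again a limit. No step from compound 1, compound 2 or compound 3 to compound 4 can be read: the limit of > 40000 nM in this assay, at which 4 of the 4 values shown sit.

The compounds shown leave open whether any group on the saturated chain carbon bound to an amide-type nitrogen would bring a compound off this limit in this assay.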